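Swapping the aromatic ring of an ester in a shared core

This account rests on a few compounds, and the source may have more. Where it says the series, first, only, none or still open, it means among the compounds named here.

Measured so far in an ADME assay on cells (Hepatocyte, Homo sapiens) for metabolic stability, with a stated time of 30 min; a higher number here means that more of the compound is left, a lower number that less of the compound is left:
- compound 1, `CS(=O)(=O)NC1CCC(CN2CCN(c3cc(=O)c4cc(C(F)(F)F)cc([N+](=O)[O-])c4s3)CC2)CC1`, gives 105%
- compound 2, `O=C(OC1CCC(CN2CCN(c3cc(=O)c4cc(C(F)(F)F)cc([N+](=O)[O-])c4s3)CC2)CC1)c1cccs1`, gives 2.2%
- compound 3, `O=C(OC1CCC(CN2CCN(c3cc(=O)c4cc(C(F)(F)F)cc([N+](=O)[O-])c4s3)CC2)CC1)c1ccncc1`, gives 1%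

Compound 3 has the lowest of the three numbers; compound 2 is close to it, while compound 1 is far higher. Compound 4, `O=C(OC1CCC(CN2CCN(c3cc(=O)c4cc(C(F)(F)F)cc([N+](=O)[O-])c4s3)CC2)CC1)c1ccccc1`, has not yet been measured; it differs from compound 3 in one place: phenyl in place of pyridin-4-yl on a carbonyl carbon.

Two kinds of step speak to this change. The steps from the methanesulfonamido compound to either ester were large: a number 102.8 percentage points lower from compound 1 to compound 2 (beyond the scatter) and a number 104 percentage points lower from compound 1 to compound 3 (beyond the scatter). The step that exchanges one aromatic ring for another on the carbonyl carbon was not: a number 1.2 percentage points lower from compound 2 to compound 3 (within the scatter). Since compound 4 keeps the ester and only changes the aromatic ring, no step beyond the scatter is expected in this assay, a number 1 percentage points higher from compound 3 to compound 4 (within the scatter).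

Compound 4 is therefore estimated at 2%, with a range from 0.5% to 12%.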

Compound 4, percent of the compound remaining: 56.4%
Beside the measured number, compound 4's estimate is 54.4 percentage points below it, outside the stated range (above it).
By their numbers in this assay, from the lowest: compounds 3 and 2 (each within the scatter of the next); then compound 4; then compound 1.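

In this assay the aromatic ring on the carbonyl carbon can decide the outcome: phenyl in place of pyridin-4-yl gives a large rise (a number 55.4 percentage points higher from compound 3 to compound 4 (beyond the scatter)), and phenyl in place of thiophen-2-yl gives a similar one (a number 54.2 percentage points higher from compound 2 to compound 4 (beyond the scatter)). Compound 2 and compound 3 lie within the scatter of each other, so the ester alone does not set a low number, and the earlier ring swap gave no sign of this. Benzoyloxy still falls well short of methanesulfonamido (a number 48.6 percentage points lower from compound 1 to compound 4 (beyond the scatter)), and nothing available explains the effect of the phenyl ring.

It remains open where a pyridin-3-yl ring or a phenyl ring carrying a chlorine would fall among these numbers. Also open, going by these compounds, is how an amide linking the benzoyl group to the saturated ring would compare with the ester in compound 4.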